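The source may report more compounds than this note shows. Statements on the series, on what has been measured and on what is new or still open speak of the compounds shown alone.

Of the compounds shown here, three built on one shared core have been measured in a functional assay on aorta with Voltage-dependent L-type calcium channel subunit alpha-1C (Oryctolagus cuniculus) as the target; on this read-out higher numbers stand for a longer-lived compound and lower numbers for a shorter-lived compound. Compound 1 `CC1=NC(C)=C(C(=O)OCCCN2C(=O)c3ccccc3S2(=O)=O)C(c2cccc([N+](=O)[O-])c2)/C1=C(\O)OC(C)C` gives 0.0783 h. Compound 2 `CO/C(O)=C1\C(C)=NC(C)=C(C(=O)OCCCN2C(=O)c3ccccc3S2(=O)=O)C1c1cccc(Cl)c1Cl` gives 0.283 h, and compound 3 `CCO/C(O)=C1\C(C)=NC(C)=C(C(=O)OCCCN2C(=O)c3ccccc3S2(=O)=O)C1c1cccc(Cl)c1Cl` gives 0.2 h, the second highest of the three numbers, nearest to compound 2 and furthest from compound 1. For the measured compounds named here, the only measured step that changes one place, a 1.4-fold lower number from compound 2 to compound 3 (0.15 log units; within the scatter), stays within the scatter. Going by the values given here, compound 4 `CC1=NC(C)=C(C(=O)OCCCN2C(=O)c3ccccc3S2(=O)=O)C(c2cccc(Cl)c2Cl)/C1=C(\O)OC(C)C` differs from compound 3 by methyl in place of hydrogen on a saturated chain carbon bound to an oxygen on an unsaturated carbon and a saturated chain carbon, which is the same kind of change as the one measured between compound 2 and compound 3, read one bond further out. Compound 1 also carries an isopropoxy group but differs from compound 4 elsewhere, so its value speaks to compound 4 only loosely. Given the single relevant step, compound 4 is expected to show no step beyond the scatter in this assay, if anything a slightly lower number, a 1.2-fold lower number from compound 3 to compound 4 (0.07 log units; within the scatter). Compound 4 is therefore estimated at 0.17 h, with a range from 0.09 h to 0.32 h.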

Compound 4, half-life: 0.185 h
Beside the measured number, compound 4's estimate is 1.1-fold (0.04 log units) below it; the measured number falls inside the stated range.
By their numbers in this assay, from the lowest: compound 1; then compounds 4, 3 and 2 (each within the scatter of the next).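

With 2,3-dichlorophenyl held fixed, ethoxy to isopropoxy on the oxygen leaves the half-life within the scatter in this assay (a 1.1-fold lower number from compound 3 to compound 4 (0.03 log units; within the scatter)), and the wider change from methyl to isopropyl at the same oxygen also stays within it (a 1.5-fold lower number from compound 2 to compound 4 (0.18 log units; within the scatter)), so these three compounds show this position tolerating branching without a readable shift. For the compounds shown here, with the isopropoxy group held fixed, the other single-place change, on a saturated ring carbon, gives the only new step beyond the scatter (a 2.4-fold higher number from compound 1 to compound 4 (0.37 log units; beyond the scatter)), which places the one modest difference seen so far at that carbon rather than at the oxygen. Nothing available accounts for either result. As far as these compounds go, it remains open whether a longer chain such as n-butyl, or a cyclopropylmethyl group, on that oxygen would also stay within the scatter. From the compounds shown here alone, it is equally open whether plain phenyl or 3-chlorophenyl on the saturated ring carbon would read closer to compound 1 or to compound 4.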